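The compounds below may be only part of what the source reports. "The series", "measured", "known", "first", "only" and "open" are said of these compounds alone.

Working notes on the series

Four compounds share a common scaffold: compound 1 `c1ccc(-c2cc3n(n2)CCCC3)nc1`, compound 2 `N#Cc1ccc(-c2cc3n(n2)CCCC3)nc1`, compound 3 `O=C(Nc1ccccn1)c1cc2n(n1)CCCC2` and compound 4 `N#Cc1ccc(NC(=O)c2cc3n(n2)CCCC3)nc1`. All readings come from a functional assay on HEK293 cells for negative allosteric modulation of metabotropic glutamate receptor 5 (Rattus norvegicus), read by FLIPR and calcium flux, with a stated time of 170 s; a higher number here means a weaker inhibitor, a lower number a stronger inhibitor.

In this assay compound 1 gives 1290 nM. In this assay compound 2 gives > 10000 nM, which is a limit of the assay rather than a number (the limit of > 10000 nM in this assay, at which 1 of the 3 values shown sits). The change from compound 1 to compound 2 is cyano in place of hydrogen on an aromatic carbon, and the step it made is an at least 7.7-fold higher number from compound 1 to compound 2 (0.88 log units; beyond the scatter).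

In this assay compound 3 gives 364 nM, the lower of the two numbers recorded so far; set against compound 1 it sits beyond the scatter on the stronger side. How the core of compound 3 differs from the core of compound 1 is not broken down here.

Compound 4 is not yet measured. It differs from compound 3 by cyano in place of hydrogen on an aromatic carbon. Within the data shown here, this is the same kind of change as the one from compound 1 to compound 2; around the place, the cyano in compound 4 sits para to a large group, whereas in compound 2 it sits para to a group of 9 heavy atoms.

Among the measured compounds shown here, the expectation for compound 4 rests on compound 2, whose step an at least 7.7-fold higher number from compound 1 to compound 2 (0.88 log units; beyond the scatter) is the only precedent for this change. The step from compound 3 to compound 4 is therefore expected to be a loss of roughly an 8.2-fold higher number from compound 3 to compound 4 (0.92 log units; beyond the scatter). Compound 4 is estimated at 3000 nM in this assay, with the expected range running from 1000 nM to 10000 nM, and a fair chance that only a limit is returned.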

Compound 4, half-maximal inhibitory concentration: 90 nM
Compound 4: middle estimate off by 33-fold (1.52 log units), on the high side; the measured number lies below the stated range.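

In this assay the change from hydrogen to cyano on an aromatic carbon gave a 4.0-fold lower number from compound 3 to compound 4 (0.61 log units; beyond the scatter), so on these two cores it did not carry over in direction or in size: the same change on two cores in this assay, an at least 7.7-fold higher number (0.88 log units; beyond the scatter) from compound 1 to compound 2 and a 4.0-fold lower number (0.61 log units; beyond the scatter) from compound 3 to compound 4, at least 31-fold (1.49 log units) apart, beyond the scatter of two such steps

For compound 2 the reading of > 10000 nM is a limit of the assay and not a number: the limit of > 10000 nM in this assay, at which 1 of the 4 values shown sits.

The two pairs show that the step measured on the core of compound 1 did not foretell the step on the core of compound 3, but they do not show which feature of the cores accounts for the split, and two pairs give no rule for any further core in the series.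

Only hydrogen and cyano stand at this place in the compounds shown, so it stays open whether chlorine, a methyl group or a methoxy group there would follow the step to compound 4 or the step to compound 2. Also open, from the compounds shown here alone, is how the cyano change would read on a core joined to the same ring through a urea or a reversed amide, which would test whether the result on the core of compound 3 extends beyond that one core.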